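The source may hold more compounds than are shown below. What is called first, only, known or untested is meant among the compounds shown, and "the series" means these compounds.

Series notes. In an ADME assay on the whole organism (plasma, Rattus norvegicus, strain Sprague-Dawley) for pharmacokinetics, read by LC-MS, using cassette dosing, at a dose of 0.2 mg/kg by the intravenous route (on this read-out lower numbers stand for lower exposure and higher numbers for higher exposure at the dose given), compound 1 `CNCc1cn(S(=O)(=O)c2ccoc2)c(-c2cccnc2F)c1F` gives 41 ng.h/mL, and compound 2 `CNCc1cn(S(=O)(=O)c2cccnc2Cl)c(-c2cccnc2F)c1F` gives 33 ng.h/mL; the two numbers lie within the scatter of each other. Among the measured compounds shown here, the one measured step at the sulfonyl sulfur, a 1.2-fold lower number from compound 1 to compound 2 (0.09 log units; within the scatter), is within the scatter. Compound 3 `CNCc1cn(S(=O)(=O)c2cccnc2C)c(-c2cccnc2F)c1F` differs from compound 1 as follows: 2-methylpyridin-3-yl in place of furan-3-yl on a sulfonyl sulfur. The measured step, another group entering on the same sulfonyl sulfur, bears on it and moved nothing beyond the scatter, so no step beyond the scatter is expected in this assay in either direction. Compound 3 is therefore expected near 38 ng.h/mL, with a range from 18 ng.h/mL to 80 ng.h/mL. The implied step, a 1.1-fold lower number from compound 1 to compound 3 (0.03 log units; within the scatter), is expected to stay within the scatter.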

Compound 3, area under the concentration-time curve: 32 ng.h/mL
For compound 3 the middle estimate is 1.2-fold (0.07 log units) above the measured one, within the range that was stated.
By their numbers in this assay, from the lowest: compounds 3, 2 and 1 (each within the scatter of the next).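

In this assay the second six-membered aromatic ring on the sulfonyl sulfur, 2-methylpyridin-3-yl in place of furan-3-yl, gives a 1.3-fold lower number from compound 1 to compound 3 (0.11 log units; within the scatter) as its step. The substituent on that ring is now also tested: methyl in place of chloro on an aromatic carbon gives a 1.0-fold lower number from compound 2 to compound 3 (0.01 log units; within the scatter) and leaves the read-out within the scatter. No available evidence accounts for these readings.

From the compounds shown here alone, whether an amine or a carboxylic acid on this ring would shift exposure beyond the scatter remains open. So does the effect of a longer chain there.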